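Two limits and a third aryl sulfonamide

A few compounds are considered here, and "the series" means these few. Any claim that something is new, unique, unknown or untested is made for them only; others in the source may bear on it.

Compound 1 `O=S(=O)(Nc1ccc(Cl)c(F)c1)c1ccc(-c2cnc(C3CC3)o2)cc1` and compound 2 `Cc1ccc(NS(=O)(=O)c2ccc(-c3cnc(C4CC4)o3)cc2)cc1C` share one core and differ only in the aryl group on a sulfonamide nitrogen. In a functional assay on cells (leukaemia cell line, Homo sapiens) for inhibition, read by sulforhodamine B assay, with a stated time of 48 h (on this read-out higher numbers stand for lower toxicity in this test and lower numbers for higher toxicity in this test), compound 1 gives > 100000 nM, which is a limit of the test rather than a number. In this assay compound 2 likewise gives > 100000 nM, again a limit. Among the compounds with values here, the single step among the measured compounds, a step that the two limits leave unreadable from compound 1 to compound 2, therefore cannot be read; what the numbers show is the limit of > 100000 nM in this assay, at which 2 of the 2 values shown sit.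

Compound 3 `Cc1cc(Cl)cc(NS(=O)(=O)c2ccc(-c3cnc(C4CC4)o3)cc2)c1` is not yet measured. Relative to compound 1 it carries 3-chloro-5-methylphenyl in place of 4-chloro-3-fluorophenyl on a sulfonamide nitrogen. Both measured compounds bear on this change, each altering the aryl group on that nitrogen, yet neither gives a size, so no direction can be expected beyond the scatter. Compound 3 is expected to show a number no higher from compound 1 to compound 3 (the limit leaves the size open), an estimate resting on the two limits alone. Compound 3 is therefore estimated at 100000 nM in this assay, with an expected range from 30000 nM to 300000 nM, and most likely the test will again report only a limit.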

Compound 3, concentration lethal to 50% of the cells: 84900 nM
Compound 3: the middle estimate sits 1.2-fold (0.07 log units) above what was measured; measured number inside the range.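

Among the three compounds, only compound 3 gives a number rather than a limit in this assay, where compound 3 gives 84900 nM, so a change to the aryl group on a sulfonamide nitrogen can bring a reading inside the range of the test. Placing 3-chloro-5-methylphenyl on that nitrogen in place of 4-chloro-3-fluorophenyl gives an at least 1.1-fold lower number from compound 1 to compound 3 (0.07 log units; that floor lies within the scatter), and placing it there in place of 3,4-dimethylphenyl gives an at least 1.1-fold lower number from compound 2 to compound 3 (0.07 log units; that floor lies within the scatter). Both steps are floors that lie within the scatter, so they establish no real difference in toxicity between compound 3 and the other two, and the true size of each step stays open, with the other two compounds still held at a limit: the limit of > 100000 nM in this assay, at which 2 of the 3 values shown sit.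

The compounds shown leave open how the number would respond to a group of another kind on the aryl ring, such as an amine or a carboxylic acid, or to a longer alkyl chain on that nitrogen in place of the aryl group. They also leave open whether any change elsewhere on the shared core would move the number at all.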